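The source may hold more compounds than are shown below. What is called first, only, known or untested is meant among the compounds shown, and "the series" means these compounds.

Of the compounds shown here, three built on a shared core have been tested in a functional assay on A549 cells (Homo sapiens) for cytotoxicity, read by MTT assay, with a stated time of 72 h; a lower number here means a stronger inhibitor, a higher number a weaker inhibitor. Compound 1 `COc1ccc(/C=N/NC(=O)Nc2ccc(Oc3ccnc4cc(OCCCN5CCCCC5)c(OC)cc34)c(F)c2)c(OC)c1` gives 1400 nM. Compound 2 `COc1cc2c(Oc3ccc(NC(=O)N/N=C/c4ccc(O)cc4)cc3F)ccnc2cc1OCCCN1CCCCC1` gives 780 nM. Compound 3 `C=CCc1cccc(/C=N/NC(=O)Nc2ccc(Oc3ccnc4cc(OCCCN5CCCCC5)c(OC)cc34)c(F)c2)c1OC` gives 250 nM. On these numbers compound 2 stands second highest of the three: its neighbour is compound 1, and its step to compound 3 is the larger one.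

The unmeasured compound 4 `COc1cc2c(Oc3ccc(NC(=S)N/N=C/c4ccccc4)cc3F)ccnc2cc1OCCCN1CCCCC1` differs from compound 2 by a group of 11 heavy atoms (8 carbon, 2 nitrogen, 1 sulfur; one six-membered aromatic ring of carbon only) in place of a group of 12 heavy atoms (8 carbon, 2 nitrogen, 2 oxygen; one six-membered aromatic ring of carbon only), on a nitrogen on an aromatic ring. This change swaps the whole group on the urea nitrogen, so that the hydroxyphenyl hydrazone with its carbonyl gives way to a plain phenyl hydrazone carrying a thiocarbonyl.

Going by the values given here, none of the measured steps alters the urea itself; all three swap only the aryl ring on the carbon with a double bond to nitrogen. Those swaps gave a 1.8-fold lower number from compound 1 to compound 2 (0.25 log units; within the scatter), a 3.1-fold lower number from compound 2 to compound 3 (0.49 log units; beyond the scatter) and a 5.6-fold lower number from compound 1 to compound 3 (0.75 log units; beyond the scatter), so changes at this end of the molecule have moved the number modestly at most. Among the compounds with values here, with no precedent for the carbonyl-to-thiocarbonyl exchange, the expectation is a step of a 1.2-fold lower number from compound 2 to compound 4 (0.08 log units; within the scatter), most likely not beyond the scatter in either direction. Compound 4 is therefore estimated at 650 nM, with a range from 200 nM to 2200 nM.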

Compound 4, half-maximal inhibitory concentration: 330 nM
Beside the measured number, compound 4's estimate is 2.0-fold (0.29 log units) above it, and the stated range covers the measured number.
By their numbers in this assay, from the lowest: compounds 3 and 4 (each within the scatter of the next); then compounds 2 and 1 (each within the scatter of the next).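

The earlier steps shown here only swapped the aryl ring on the carbon with a double bond to nitrogen, whereas this change replaces the whole group on a nitrogen on an aromatic ring, with a thiocarbonyl for the carbonyl and a plain phenyl for the 4-hydroxyphenyl. The step is a 2.4-fold lower number from compound 2 to compound 4 (0.37 log units; beyond the scatter) in this assay and goes toward the stronger side, so the urea part of the molecule can be altered without losing activity in this cell assay, and the number moves by a modest amount. Nothing available here explains why the number falls.

Two things changed at once, so the step cannot be divided between the sulfur and the loss of the hydroxyl group; a thiocarbonyl compound that keeps the 4-hydroxyphenyl, or a carbonyl compound with the plain phenyl, would separate the two. Also open, going by these compounds, is how the thiocarbonyl behaves with the 3-allyl-2-methoxyphenyl ring, and what a guanidine, with a nitrogen in place of the sulfur, would do at this position.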